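This account rests on a few compounds, and the source may have more. Where it says the series, first, only, none or still open, it means among the compounds named here.

Compound 3 `CCO/N=C/Nc1cc(Cl)c(OC(C)C)c(Cl)c1` gives 4.4 in a physicochemical assay for lipophilicity, measured as octanol-water partition (on this read-out higher numbers stand for higher lipophilicity and lower numbers for lower lipophilicity), the second highest of the three numbers: compound 2 `CCO/N=C/Nc1cc(Cl)c(SSCC)c(Cl)c1` gives 5 and compound 1 `CCO/N=C/Nc1cc(Cl)cc(Cl)c1` gives 3. Both steps into compound 3 are large: a number 1.40 log units higher from compound 1 to compound 3 (beyond the scatter) and a number 0.60 log units lower from compound 2 to compound 3 (beyond the scatter), and the hydrogen-to-disulfide step is larger still, a number 2.00 log units higher from compound 1 to compound 2 (beyond the scatter). Compound 4 `CCO/N=C/Nc1cc(Cl)c(OCCCl)c(Cl)c1` differs from compound 3 by 2-chloroethyl in place of isopropyl on an oxygen on an aromatic ring. Going by the values given here, none of the measured steps swaps one substituent on that oxygen for another, so they show only that the substituent at this aromatic carbon moves the number strongly. In this assay the expected step is a number 0.40 log units lower from compound 3 to compound 4 (beyond the scatter), modest and downward, more than the scatter but far short of the measured steps. Compound 4 is estimated at 4, between 3.6 and 4.4.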

Compound 4, partition coefficient: 4
Beside the measured number, compound 4's estimate shows no gap at the digits printed; measured number inside the range.
By their numbers in this assay, from the lowest: compound 1; then compound 4; then compound 3; then compound 2.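

Changing only the group on the oxygen still moves the number in this assay (a number 0.40 log units lower from compound 3 to compound 4 (beyond the scatter)), so the read-out at this position depends on more than the atom attached to the aromatic carbon. The 2-chloroethoxy group also sits clear of both hydrogen (a number 1.00 log units higher from compound 1 to compound 4 (beyond the scatter)) and (ethylsulfanyl)sulfanyl (a number 1.00 log units lower from compound 2 to compound 4 (beyond the scatter)). No measurement shown here accounts for these steps.

Still open, from the compounds shown here alone, is where a longer chain, a hydroxyl-bearing chain or an amine on that oxygen would fall. Also open, going by these compounds, is whether 2-chloroethyl in place of isopropyl gives a similar step on a different core.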